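Iodo to methyl on an amino compound

The source may report more compounds than this note shows. Statements on the series, on what has been measured and on what is new or still open speak of the compounds shown alone.

In a functional assay on FM3A cells (Mus musculus) for antiproliferative activity, with a stated time of 48 h (a higher number here means a weaker inhibitor, a lower number a stronger inhibitor), compound 1 (`C=C(Br)C(=O)Nc1ccc(/C=C/C(=O)c2ccc(C)cc2)cc1`) gives 2100 nM, compound 2 (`Nc1ccc(/C=C/C(=O)c2ccc(Cl)cc2)cc1`) gives 178000 nM and compound 3 (`Nc1ccc(/C=C/C(=O)c2ccc(I)cc2)cc1`) gives 110000 nM. Compound 3 is thus the second highest of the three numbers, within the scatter of compound 2 and far above compound 1. Compound 4 (`Cc1ccc(C(=O)/C=C/c2ccc(N)cc2)cc1`) differs from compound 3 by methyl in place of iodo on an aromatic carbon. Within the data shown here, the only measured step at that carbon is a 1.6-fold lower number from compound 2 to compound 3 (0.21 log units; within the scatter), and it lies within the scatter. No change beyond the scatter is therefore expected in this assay, and the expected step is a 1.1-fold higher number from compound 3 to compound 4 (0.04 log units; within the scatter). The estimated value for compound 4 is 120000 nM, with an expected range of 50000 nM to 280000 nM.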

Compound 4, half-maximal inhibitory concentration: 107000 nM
The estimate for compound 4 lay 1.1-fold (0.05 log units) above the measured number; the measured number falls inside the stated range.
By their numbers in this assay, from the lowest: compound 1; then compounds 4, 3 and 2 (each within the scatter of the next).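

In this assay, methyl at this carbon, para to a large group, brings no change beyond the scatter from iodo, with a 1.0-fold lower number from compound 3 to compound 4 (0.01 log units; within the scatter), or from chloro, with a 1.7-fold lower number from compound 2 to compound 4 (0.22 log units; within the scatter). Compound 4 also isolates the change on the nitrogen, where hydrogen in place of (1-bromoethenyl)carbonyl gives a 51-fold higher number from compound 1 to compound 4 (1.71 log units; beyond the scatter), with methyl held constant.

From the compounds shown here alone, whether methoxy or nitrile at this carbon would fit the same picture remains open, as does whether (1-bromoethenyl)carbonyl on the nitrogen gives a similar step with iodo or chloro there. Nothing given here offers an explanation for these results.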